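The source may report more compounds than this note shows. Statements on the series, on what has been measured and on what is new or still open speak of the compounds shown alone.

Measured in a functional assay on KB cells (Homo sapiens) for antiproliferative activity, read by MTT assay, with a stated time of 72 h; a higher number here means a weaker inhibitor, a lower number a stronger inhibitor:
- Compound 1 `CCOC(=O)c1cc(-c2ccc(OC)c([N+](=O)[O-])c2)c(-c2cc(OC)c(OC)c(OC)c2)s1`: 24000 nM
- Compound 2 `CCOC(=O)c1cc(-c2ccc(OC)c(OCc3ccccc3)c2)c(-c2cc(OC)c(OC)c(OC)c2)s1`: > 100000 nM (a limit of the assay, not a number)

Compound 2 has no number of its own and stands at the limit of > 100000 nM in this assay, at which 1 of the 2 values shown sits. For the measured compounds named here, the only measured step is an at least 4.1-fold higher number from compound 1 to compound 2 (0.61 log units; beyond the scatter), with benzyloxy in place of nitro on an aromatic carbon.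

Compound 3 `COc1ccc(-c2cc(C(=O)O)sc2-c2cc(OC)c(OC)c(OC)c2)cc1OCc1ccccc1` keeps that benzyloxy group and the rest of compound 2, and changes elsewhere: hydrogen in place of ethyl on an oxygen next to a carbonyl group, or ethoxycarbonyl to carboxy (hydrogen in place of ethyl on an oxygen next to a carbonyl group). Going by the values given here, no measured step touches this place, so the step from compound 1 to compound 2 gives no size for the new change. It bears only on the starting point, which is the weak end of this assay.

No shift beyond the scatter is therefore expected, and a further limit in place of a number is quite likely. The expected change is a number no higher from compound 2 to compound 3 (the limit leaves the size open). For compound 3 the estimated value is 100000 nM, with an expected range of 30000 nM to 200000 nM.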

Compound 3, half-maximal inhibitory concentration: > 100000 nM
Compound 3: only a limit was reported; the forecaster's own chance of this, stated with the estimate: 65%; the middle value sits exactly at the limit.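

In this assay compound 3 gives > 100000 nM, a limit of the assay and not a number. Compound 2 also stands at a limit, so no step between compound 2 and compound 3 can be read: the limit of > 100000 nM in this assay, at which 2 of the 3 values shown sit.

The compounds shown leave open the size of any effect of ethoxycarbonyl to carboxy in this assay.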